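Amide-for-acid swap on the thiazole aniline series

This account rests on a few compounds, and the source may have more. Where it says the series, first, only, none or still open, it means among the compounds named here.

Measured so far:
- compound 1, `Cc1nc(-c2ccc(C(F)(F)F)cc2)sc1CNc1ccc(CCC(=O)O)cc1`, 108% in a functional assay on CHO cells for agonist activity at Free fatty acid receptor 1 (Homo sapiens), read by a luciferase reporter; a higher number here means a larger maximal response, a lower number a smaller maximal response
- compound 2, `CC(CC(=O)O)c1ccc(NCc2cccc(Oc3ccccc3)c2)cc1`, 83% in this assay

Compound 1 gives the highest of the two values in this assay; compound 2 sits a step below it that lies beyond the usual scatter. Compound 3, `Cc1nc(-c2ccc(C(F)(F)F)cc2)sc1CNc1ccc([C@H]2C[C@@H]2C(N)=O)cc1`, is not yet measured and differs from compound 1 in one place: 2-carbamoylcyclopropyl in place of 2-carboxyethyl on an aromatic carbon. Among the measured compounds shown here, no measured pair shows this kind of exchange, so the size of its effect is unknown. For the measured compounds named here, both compounds measured so far carry a carboxylic acid on the chain, and compound 1 with its 2-carboxyethyl reaches 108%; with the acid gone and a neutral amide on a three-membered ring in its place, the maximal response of compound 3 is expected to drop, and the step of a number 53 percentage points lower from compound 1 to compound 3 (beyond the scatter) is expected to fall beyond the scatter. The estimate for compound 3 is 55%, within 15% to 105%.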

Compound 3, largest response reached (reported as percent of maximum), in percent of the reference or control that the assay uses: 80%
Compound 3: middle estimate off by 25 percentage points, on the low side, and the stated range covers the measured number.
By their numbers in this assay, from the lowest: compounds 3 and 2 (each within the scatter of the next); then compound 1.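

Among the compounds shown here, at the aromatic carbon para to a large group, 2-carbamoylcyclopropyl in place of 2-carboxyethyl gives a number 28 percentage points lower from compound 1 to compound 3 (beyond the scatter) in this assay and is the only exchange read at this position so far. Compound 3 still reaches 80% in this assay without a carboxylic acid, so on the shared core a carboxylic acid is not required for a sizeable maximal response, although the step lies beyond the scatter. Nothing measured accounts for the drop.

This single step changes both the end group and the chain, so the amide and the three-membered ring cannot be separated. On these data alone, a 2-carbamoylethyl chain and a 2-carboxycyclopropyl group would divide the step between them, and the role of the two defined stereocentres stays open, as the opposite cyclopropane stereoisomer would show.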